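Unchanged core, new side chain, likely still inactive

The compounds below may be only part of what the source reports. "The series", "measured", "known", "first", "only" and "open" are said of these compounds alone.

Compound 1 `CC(C)(C)OC(=O)N1CCN(C(=S)SCc2cn(C[C@H](O)[C@H]3OC(=O)C(OCc4ccccc4)=C3OCc3ccccc3)nn2)CC1`: in a functional assay on HepG2 cells (Homo sapiens) for antiproliferative activity, read by MTT assay, with a stated time of 72 h (a higher number here means a weaker inhibitor, a lower number a stronger inhibitor), compound 1 gives only an assay limit, > 100000 nM.
Compound 2 `COc1ccccc1-c1cn(C[C@H](O)[C@H]2OC(=O)C(OCc3ccccc3)=C2OCc2ccccc2)nn1`: in this assay compound 2 gives only an assay limit, > 100000 nM.
Compound 3 `COc1ccccc1-c1cn(C/C=C2\OC(=O)C(OCc3ccccc3)=C2OCc2ccccc2)nn1`: in this assay compound 3 gives only an assay limit, > 100000 nM.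

The three measured compounds share the same core and differ in the group attached to the five-membered aromatic ring with three nitrogens and in the linker to it. None of them gives a number in this assay; all three sit at the limit of > 100000 nM in this assay, at which 3 of the 3 values shown sit. For the measured compounds named here, compound 2 therefore stands nowhere in particular among them: it is at the limit, as are the other two, and no measured pair differs in one place, so no measured step is available.

Compound 4 `O=C1O[C@H]([C@@H](O)Cn2cc(CNS(=O)(=O)c3ccc(Cl)cc3)nn2)C(OCc2ccccc2)=C1OCc1ccccc1` differs from compound 2 by (((4-chlorophenyl)sulfonyl)amino)methyl in place of 2-methoxyphenyl on an aromatic carbon.

Since every measured value is a limit, there is nothing to suggest that this change moves the result out of the inactive range. The expected step is a number no higher from compound 2 to compound 4 (the limit leaves the size open), that is, no change beyond the scatter. Compound 4 is accordingly estimated at 100000 nM, with a range from 20000 nM to 300000 nM, and the measurement is expected most likely to come back as a limit again.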

Compound 4, half-maximal inhibitory concentration: 7510 nM
Compound 4: the middle estimate sits 13-fold (1.12 log units) above what was measured, and the stated range ends above it.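

Placing (((4-chlorophenyl)sulfonyl)amino)methyl in place of 2-methoxyphenyl on this aromatic carbon gives the only actual number among the compounds shown in this assay, and the step reads an at least 13-fold lower number from compound 2 to compound 4 (1.12 log units; beyond the scatter). Compounds 2 and 4 differ in this one place, so the shared core can give a measurable effect in these cells when this position carries the right group, and the choice of group here can decide between a limit and a number. The true size of the step stays unknown because compound 2 gives only a limit, the result that also dominates this small set: the limit of > 100000 nM in this assay, at which 3 of the 4 values shown sit.

From the compounds shown here alone, the entering group differs from the leaving one in several ways at once, so it remains open whether the sulfonyl, the amino hydrogen, the chlorine or the methylene link accounts for the step. Comparing compound 4 with a close relative carrying a carboxamide in place of the sulfonyl, or a phenyl ring with hydrogen in place of the chlorine, would begin to separate these parts.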